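Fluoropyridine for fluorophenyl in a benzamide thiourea series

The source may report more compounds than this note shows. Statements on the series, on what has been measured and on what is new or still open speak of the compounds shown alone.

Two thioureas sharing the same core have been measured. Compound 1 `Nc1ccccc1NC(=O)c1ccc(NC(=S)NCc2cncc(Br)c2)cc1` gives 7500 nM in a functional assay on HepG2 cells (Homo sapiens) for cytotoxicity, read by MTT assay, with a stated time of 72 h; on this read-out higher numbers stand for weaker inhibition and lower numbers for stronger inhibition. Compound 2 `Nc1ccccc1NC(=O)c1ccc(NC(=S)NCc2cccc(F)c2)cc1` gives 2900 nM in this assay. Among the measured compounds shown here, the one step between them, a 2.6-fold lower number from compound 1 to compound 2 (0.41 log units; beyond the scatter), is the only comparison available, and it changes both the halogen and the ring, so it does not separate the two parts of the change. On the numbers shown, compound 2 stands with the lowest number of the two, its nearest neighbour being compound 1.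

Compound 3 `Nc1ccccc1NC(=O)c1ccc(NC(=S)NCc2cncc(F)c2)cc1` is not yet measured. It differs from compound 2 in one place: 5-fluoropyridin-3-yl in place of 3-fluorophenyl on a saturated chain carbon bound to an amide-type nitrogen. This reintroduces the pyridine ring of compound 1 while keeping the fluorine of compound 2, so it undoes part of the step from compound 1 to compound 2. For the measured compounds named here, the only bearing step, a 2.6-fold lower number from compound 1 to compound 2 (0.41 log units; beyond the scatter), was modest. A step of similar size in the opposite direction, or a smaller one, is therefore expected, giving a 1.7-fold higher number from compound 2 to compound 3 (0.24 log units; within the scatter). For compound 3 the estimate in this assay is 5000 nM, with a range from 2000 nM to 12000 nM.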

Compound 3, half-maximal inhibitory concentration: 13000 nM
For compound 3 the middle estimate is 2.6-fold (0.41 log units) below the measured one, and the stated range ends below it.
By their numbers in this assay, from the lowest: compound 2; then compounds 1 and 3 (each within the scatter of the next).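

Holding the fluorine fixed isolates the ring for the first time: in this assay, 5-fluoropyridin-3-yl in place of 3-fluorophenyl on a saturated chain carbon bound to an amide-type nitrogen gives a 4.5-fold higher number from compound 2 to compound 3 (0.65 log units; beyond the scatter) and so lies beyond the scatter. Holding the pyridine ring fixed isolates the halogen, and fluoro in place of bromo on an aromatic carbon gives a 1.7-fold higher number from compound 1 to compound 3 (0.24 log units; within the scatter) and so lies within the scatter, which means that this pair shows no readable effect of the halogen and that, among these three compounds, the ring change alone produces a step beyond the scatter. Nothing in the data shown gives a cause for the ring step.

The compounds shown leave open whether a 3-bromophenyl group would give the same ring step with bromine in place of fluorine, which would complete the comparison of both rings with both halogens. They also leave open how an unsubstituted phenyl or pyridin-3-yl group, a 3-chlorophenyl group or a 3-methoxyphenyl group would read at this position.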